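Swapping Methyl for Methoxy on Compound 1

The source may report more compounds than this note shows. Statements on the series, on what has been measured and on what is new or still open speak of the compounds shown alone.

Among the compounds with values here, in a functional assay on HeLa cells (Homo sapiens) for cytotoxicity, read by MTT assay, with a stated time of 48 h (a lower number here means a stronger inhibitor, a higher number a weaker inhibitor), compound 1 `COC(=O)[C@@H](NC(=O)CSC1=C(C)C(=O)c2ccccc2C1=O)C(C)C` gives 20000 nM, the only true number among the three compounds measured so far. Compound 2 `COC(=O)CNC(=O)CSC1=CC(=O)c2cccc(OC)c2C1=O` reaches only a limit of the assay, > 100000 nM. Compound 3 `COC(=O)[C@H](CC(C)C)NC(=O)CSC1=C(C)C(=O)c2cccc(OC)c2C1=O` likewise gives only a limit, > 100000 nM. The next compound to be tested, compound 4 `COC(=O)[C@@H](NC(=O)CSC1=C(OC)C(=O)c2ccccc2C1=O)C(C)C`, keeps the core and side chain of compound 1 but carries methoxy in place of methyl on a double-bonded ring carbon. Within the data shown here, no measured pair isolates this swap, so only a small shift towards weaker inhibition in this assay is expected, possibly none beyond the scatter. The expected change is a 1.5-fold higher number from compound 1 to compound 4 (0.18 log units; within the scatter). For compound 4 the estimated value is 30000 nM, with an expected range of 8000 nM to 100000 nM.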

Compound 4, half-maximal inhibitory concentration: 93500 nM
For compound 4 the middle estimate is 3.1-fold (0.49 log units) below the measured one, and the stated range covers the measured number.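

Within the data shown here, this is the first readable change at this position. In this assay, methoxy in place of methyl on a double-bonded ring carbon gives a 4.7-fold higher number from compound 1 to compound 4 (0.67 log units; beyond the scatter), so the group held here matters, at least with the core and side chain of compound 1. Compound 4 now sits close to the top of the readable scale, leaving little room to follow any further weakening: the limit of > 100000 nM in this assay, at which 2 of the 4 values shown sit.

From the compounds shown here alone, what an amine or an ethyl group in this place would give remains open. So does whether any group here could give a lower number than compound 1 does.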